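Methyl for Chloro on the Benzyl Sulfide

A few compounds are considered here, and "the series" means these few. Any claim that something is new, unique, unknown or untested is made for them only; others in the source may bear on it.

In a functional assay on DU-145 cells (Homo sapiens) for inhibition, read by trypan blue exclusion, with a stated time of 96 h (on this read-out higher numbers stand for weaker inhibition of growth and lower numbers for stronger inhibition of growth), the three measured compounds stand as follows:
Compound 1 `O=C(/C(=C\c1ccc(O)c([N+](=O)[O-])c1)SCc1ccc(Cl)cc1)c1ccc(Cl)cc1`: 10000 nM
Compound 2 `O=C(/C(=C\c1ccc(O)cc1O)SCc1ccc(Cl)cc1)c1ccc(Cl)cc1`: 50000 nM
Compound 3 `COc1ccccc1/C=C(/SCc1ccc(Cl)cc1)C(=O)c1ccc(Cl)cc1`: 1000 nM

Compound 3 holds the lowest number of the three, with a 10-fold lower number from compound 1 to compound 3 (1.00 log units; beyond the scatter) and a 50-fold lower number from compound 2 to compound 3 (1.70 log units; beyond the scatter) separating it from the other two. Compound 4 `COc1ccccc1/C=C(/SCc1ccc(C)cc1)C(=O)c1ccc(Cl)cc1` differs from compound 3 in one place: methyl in place of chloro on an aromatic carbon. Among the compounds with values here, none of the measured steps bears on this change; every one of them replaces the aryl group on the double-bonded chain carbon, and the (4-chlorobenzyl)sulfanyl group is unchanged throughout. Within the data shown here, with no step to draw on, the expected change is a 1.5-fold higher number from compound 3 to compound 4 (0.18 log units; within the scatter), not beyond the scatter. Compound 4 is therefore estimated at 1500 nM, within 500 nM to 5000 nM.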

Compound 4, concentration for 50% growth inhibition: 10000 nM
Compound 4: middle estimate off by 6.7-fold (0.82 log units), on the low side; measured number above the stated range.
By their numbers in this assay, from the lowest: compound 3; then compounds 1 and 4 (each within the scatter of the next); then compound 2.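

Within the data shown here, the (4-chlorobenzyl)sulfanyl group stayed fixed through the earlier compounds, so only now does this position show that it matters: in this assay, methyl in place of chloro on the aromatic carbon para to a large group gives a 10-fold higher number from compound 3 to compound 4 (1.00 log units; beyond the scatter). That step has the same size as the one printed for the aryl exchange, a 10-fold lower number from compound 1 to compound 3 (1.00 log units; beyond the scatter), though in the opposite direction. Nothing measured here accounts for the change.

From the compounds shown here alone, whether fluoro, methoxy or plain hydrogen at this place would track chloro or methyl remains open. So does whether the step would recur with the 4-hydroxy-3-nitrophenyl group of compound 1 in place of 2-methoxyphenyl.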